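This account rests on a few compounds, and the source may have more. Where it says the series, first, only, none or still open, it means among the compounds named here.

Compound 1 `COc1ccc(C2=NN(C3=NC(=O)/C(=C4\C(=O)Nc5ccccc54)S3)C(c3ccc(OC)cc3)C2)cc1` gives 99600 nM in a functional assay on cells (Cancer cell lines, Homo sapiens) for cytotoxicity, read by sulforhodamine B assay, with a stated time of 48 h; on this read-out higher numbers stand for weaker inhibition of growth and lower numbers for stronger inhibition of growth. Compound 2 `COc1ccc(C2=NN(C3=NC(=O)/C(=C4\C(=O)Nc5ccc(Cl)cc54)S3)C(c3ccc(OC)cc3)C2)cc1` gives 500 nM in this assay, and compound 3 `COc1ccc(C2=NN(C3=NC(=O)/C(=C4\C(=O)Nc5ccccc54)S3)C(c3ccc(Cl)cc3)C2)cc1` gives 100000 nM. Among these three numbers compound 3 stands highest; the step of a 1.0-fold higher number from compound 1 to compound 3 (0.00 log units; within the scatter) lies within the scatter, so compound 1 and compound 3 cannot be set in order, whereas compound 2 sits far below both, with the step of a 200-fold lower number from compound 1 to compound 2 (2.30 log units; beyond the scatter) well beyond the scatter.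

Compound 4 `COc1ccc(C2=NN(C3=NC(=O)/C(=C4\C(=O)Nc5ccc(Cl)cc54)S3)C(c3ccc(Cl)cc3)C2)cc1` has not yet been measured. It differs from compound 3 by chloro in place of hydrogen on an aromatic carbon. For the measured compounds named here, the only step that bears on this change is the one from compound 1 to compound 2, which is the same exchange on the same ring and gave a 200-fold lower number from compound 1 to compound 2 (2.30 log units; beyond the scatter). The change from methoxy to chloro on the other aryl ring, seen in a 1.0-fold higher number from compound 1 to compound 3 (0.00 log units; within the scatter), made no difference beyond the scatter, so nothing in hand suggests that this second ring would blunt the effect.

A step of about the same size is therefore expected, a 170-fold lower number from compound 3 to compound 4 (2.22 log units; beyond the scatter), towards stronger growth inhibition. For compound 4 the estimate in this assay is 600 nM, with a range from 150 nM to 5000 nM.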

Compound 4, concentration for total growth inhibition: 470 nM
For compound 4 the middle estimate is 1.3-fold (0.11 log units) above the measured one; measured number inside the range.
By their numbers in this assay, from the lowest: compounds 4 and 2 (each within the scatter of the next); then compounds 1 and 3 (each within the scatter of the next).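

The gain from chloro in place of hydrogen at this position of the fused two-ring system in this assay now holds on a second core, with a 210-fold lower number from compound 3 to compound 4 (2.33 log units; beyond the scatter), so it no longer rests on a single pair: the same change on two cores in this assay, a 200-fold lower number (2.30 log units; beyond the scatter) from compound 1 to compound 2 and a 210-fold lower number (2.33 log units; beyond the scatter) from compound 3 to compound 4, 1.1-fold (0.03 log units) apart, within the scatter of two such steps

With chloro already on the fused system, chloro in place of methoxy on the other aryl ring still gives no step beyond the scatter, with a 1.1-fold lower number from compound 2 to compound 4 (0.03 log units; within the scatter): the same change on two cores in this assay, a 1.0-fold higher number (0.00 log units; within the scatter) from compound 1 to compound 3 and a 1.1-fold lower number (0.03 log units; within the scatter) from compound 2 to compound 4, 1.1-fold (0.03 log units) apart, within the scatter of two such steps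

Across these four compounds the two exchanges therefore behave independently, and none of the four goes against this.

The compounds shown leave open whether the large step is particular to chloro or would also appear with fluoro, methyl, methoxy, an amine or a carboxylic acid at this position. Also open, as far as these compounds go, is whether chloro on the other carbons of this ring would give a similar step.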